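This account rests on a few compounds, and the source may have more. Where it says the series, first, only, none or still open, it means among the compounds named here.

In a functional assay on cells (Platelet, Oryctolagus cuniculus) for inhibition, read by turbidimetry, with a stated time of 5 min (on this read-out lower numbers stand for stronger inhibition and higher numbers for weaker inhibition), three compounds have been measured. Compound 1 `CCCC[C@H]1NC(=O)c2ccccc21` gives 1150000 nM in this assay. Compound 3 `CCCC[C@H](OC(=O)CN1CCCC1)c1ccccc1C(=O)O[C@H]1CO[C@H]2[C@@H]1OC[C@H]2OC(=O)c1ccccc1[C@H](CCCC)OC(=O)CN1CCCC1` gives 800000 nM. Compound 2 `CCCC[C@H](OC(C)=O)c1ccccc1C(=O)O[C@H]1CO[C@H]2[C@@H]1OC[C@H]2OC(=O)c1ccccc1[C@H](CCCC)OC(C)=O` gives 330000 nM, the lowest number of the three; its gaps to compound 3 and to compound 1 both lie beyond the usual scatter, so among the measured compounds compound 2 is the strongest inhibitor, though all three remain weak. Among the compounds with values here, compound 4 `CCCC[C@@H](OC(C)=O)c1ccccc1C(=O)O[C@H]1CO[C@H]2[C@@H]1OC[C@H]2OC(=O)c1ccccc1[C@@H](CCCC)OC(C)=O` has not yet been measured in this assay. the two compounds have the same atoms and bonds and differ only in configuration as drawn: 2 of 6 stereo elements differ; a stereocentre at a saturated chain carbon is drawn S in compound 2 and R in compound 4; a stereocentre at a saturated chain carbon is drawn S in compound 2 and R in compound 4 No pair of measured compounds differs in a single place, so no reference step of this kind is available, and what can be said about compound 4 rests only on the weak numbers seen so far and on the nature of the change, which alters configuration alone. The expected step is a 1.5-fold higher number from compound 2 to compound 4 (0.18 log units; within the scatter), a modest rise in the number, and it may well fall within the scatter. Compound 4 is therefore expected to give about 500000 nM in this assay, with a range from 150000 nM to 1500000 nM.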

Compound 4, half-maximal inhibitory concentration: 710000 nM
Beside the measured number, compound 4's estimate is 1.4-fold (0.15 log units) below it; low and high end bracket the measured number.
By their numbers in this assay, from the lowest: compound 2; then compounds 4, 3 and 1 (each within the scatter of the next).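

In this assay, the configuration at the two saturated chain carbons proves to matter, though only modestly: redrawing both from S to R gives a 2.2-fold higher number from compound 2 to compound 4 (0.33 log units; beyond the scatter). Within the data shown here, the earlier compounds offered no comparison of this kind, as no two of them differed in a single place, and this pair provides the first reference step for the series. The rise in the number can be assigned to configuration alone, because no atom or bond changes within the pair: the fact that compounds 2 and 4 differ only in the configuration as drawn.

The compounds shown leave open whether inverting just one of the two stereocentres would give part of this step or all of it. They also leave open whether the same inversion would count for as much with a longer chain at those carbons, or with a carboxylic acid in place of the acetyl ester.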